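Estimating Compound 4 Without a Starting Value

The source may hold more compounds than are shown below. What is called first, only, known or untested is meant among the compounds shown, and "the series" means these compounds.

Values in an ADME assay on L6 cells (Rattus norvegicus) for cytotoxicity; on this read-out lower numbers stand for stronger inhibition and higher numbers for weaker inhibition:
- compound 1 `OC[C@H]1O[C@@H](n2cnc3c(NC4CCCC4)nc(NC4CCCC4)nc32)[C@H](O)[C@@H]1O`: 97300 nM
- compound 2 `OC[C@H]1O[C@@H](n2cnc3c(NC4CCCC4)nc(NCCOCc4ccccc4)nc32)[C@H](O)[C@@H]1O`: 78800 nM
- compound 3 `COc1nc(Nc2ccccc2)c2ncn([C@@H]3O[C@H](CO)[C@@H](O)[C@H]3O)c2n1`: "not determined" (no result reported)

Compound 3 has no single number, so it offers no starting point. In compound 4 `OC[C@H]1O[C@@H](n2cnc3c(Nc4ccccc4)nc(NC4CCCC4)nc32)[C@H](O)[C@@H]1O`, cyclopentylamino takes the place of methoxy on an aromatic carbon (cyclopentylamino in place of methoxy on an aromatic carbon). Among the compounds with values here, the only measured step is a 1.2-fold lower number from compound 1 to compound 2 (0.09 log units; within the scatter), and it concerns a different change, so it gives no size for this one. Within the data shown here, no step from compound 3 can therefore be expected in this assay. The expectation rests instead on compound 1, which also carries cyclopentylamino and gives 97300 nM. For compound 4 the expected value is 80000 nM, with an estimated range of 30000 nM to 200000 nM.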

Compound 4, half-maximal inhibitory concentration: 36300 nM
The estimate for compound 4 lay 2.2-fold (0.34 log units) above the measured number; measured number inside the range.
By their numbers in this assay, from the lowest: compound 4; then compounds 2 and 1 (each within the scatter of the next).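

With cyclopentylamino kept on the aromatic carbon between two ring nitrogen atoms, phenyl in place of cyclopentyl on the other amino nitrogen gives a 2.7-fold lower number from compound 1 to compound 4 (0.43 log units; beyond the scatter) in this assay. This is the first change among these compounds to move the number beyond the scatter, and it does so modestly. Compound 3 has no number, which leaves the methoxy to cyclopentylamino change unreadable, and no evidence on the cause of the new step is at hand. Going by these compounds, whether a benzyl or pyridyl group on that nitrogen would shift the number in the same direction stays open.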